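Quinoxaline-type diamines: linker and aryl change at the ring carbon

A few compounds are considered here, and "the series" means these few. Any claim that something is new, unique, unknown or untested is made for them only; others in the source may bear on it.

Measured so far:
compound 1 `Nc1cc(N)c2nc(-c3ccccc3)c(NCc3ccc(F)cc3)nc2c1` — 15500 nM
compound 2 `COc1ccc(Sc2nc3cc(N)cc(N)c3nc2-c2ccccc2)cc1` — 5130 nM
compound 3 `Nc1cc(N)c2nc(-c3ccccc3)c(Sc3ccc(Cl)c(Cl)c3)nc2c1` — 15500 nM

All three share one core and differ only in the group on the aromatic carbon next to the ring nitrogen. In a functional assay on PC-3 cells (Homo sapiens) for inhibition, read by sulforhodamine B assay, with a stated time of 48 h (a higher number here means a weaker inhibitor of growth, a lower number a stronger inhibitor of growth), compound 3 gives 15500 nM, level with compound 1 at the digits shown, the two together standing at the highest numbers of the set. The gap is a 3.0-fold higher number from compound 2 to compound 3 (0.48 log units; beyond the scatter), and the step of no change at the digits printed from compound 1 to compound 3 (within the scatter) shows that swapping the (4-fluorobenzyl)amino group for the (3,4-dichlorophenyl)sulfanyl group did not move the number.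

The step to compound 4 `Nc1cc(N)c2nc(-c3ccccc3)c(Oc3ccc(F)cc3)nc2c1` is 4-fluorophenoxy in place of (3,4-dichlorophenyl)sulfanyl on an aromatic carbon. Going by the values given here, two measured steps bear on it. a 3.0-fold higher number from compound 2 to compound 3 (0.48 log units; beyond the scatter) shows that the ring substituents on the sulfur-linked aryl matter modestly, and no change at the digits printed from compound 1 to compound 3 (within the scatter) shows a change of linker and aryl together leaving the number where it was. Among the compounds with values here, compound 4 keeps the 4-fluoro aryl seen in compound 1 but through an oxygen; no measured pair isolates the oxygen linker. The expected step is therefore small, a 1.6-fold lower number from compound 3 to compound 4 (0.19 log units; within the scatter), leaning toward a lower number on the strength of the pattern in compound 2. Compound 4 is estimated at 10000 nM, with a range from 3000 nM to 30000 nM.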

Compound 4, concentration for total growth inhibition: 27500 nM
Compound 4: the middle estimate sits 2.8-fold (0.44 log units) below what was measured, within the range that was stated.
By their numbers in this assay, from the lowest: compound 2; then compounds 1, 3 and 4 (each within the scatter of the next).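

In this assay, the 4-fluorophenoxy group of compound 4 gives no separation from the sulfur-linked or nitrogen-linked groups of the two nearest compounds, with a 1.8-fold higher number from compound 3 to compound 4 (0.25 log units; within the scatter) and a 1.8-fold higher number from compound 1 to compound 4 (0.25 log units; within the scatter). Only the (4-methoxyphenyl)sulfanyl group stands apart, with a 5.4-fold higher number from compound 2 to compound 4 (0.73 log units; beyond the scatter), which extends the earlier picture: compound 2 now has a step beyond the scatter to each of the other three, and this position tolerates an oxygen-linked aryl without reaching the number of compound 2, though compounds 1, 3 and 4 cannot be ordered among themselves. No measurement shown here accounts for the gap between compound 2 and compound 4.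

No pair shown holds the aryl group fixed while only the linking atom changes, leaving the separate contributions of the oxygen and the sulfur unresolved, and compound 2 remains the only evidence that a methoxy-bearing aryl group gives a lower number. A 4-methoxyphenoxy group would pair directly with compound 2 to test the linker alone, while a morpholine or a longer alkyl chain at this carbon would show whether an aryl group is needed at all.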